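Halogen swap on the shared core, compound 4 to come

A few compounds are considered here, and "the series" means these few. Any claim that something is new, unique, unknown or untested is made for them only; others in the source may bear on it.

Compound 1 `CC1CCN(c2c(S(=O)(=O)c3ccc(F)cc3)cnc3ccc(F)cc23)CC1` and compound 2 `CC1CCN(c2c(S(=O)(=O)c3ccc(F)cc3)cnc3ccc(Cl)cc23)CC1` differ in one place only, (chloro in place of fluoro on an aromatic carbon). In an assay on isolated protein for displacement of a labelled ligand from metabotropic glutamate receptor 5 (Homo sapiens), with a stated time of 60 min, tested at 1 uM (a lower number here means less inhibition, a higher number more inhibition at the concentration tested (going by the name of the read-out)), compound 1 gives 87%, and compound 2 gives 89%; the step is a number 2 percentage points higher from compound 1 to compound 2 (within the scatter). Compound 3 `CC1CCN(c2c(S(=O)(=O)c3ccc(Cl)cc3)cnc3cc(F)ccc23)CC1` rests on the core of compound 3 rather than the core of compound 1; the difference between the two cores is not broken down here. In this assay compound 3 gives 90%, a value within the scatter of those of compound 2 and compound 1, so no order among the three is claimed. Compound 4 `CC1CCN(c2c(S(=O)(=O)c3ccc(Cl)cc3)cnc3cc(Cl)ccc23)CC1` is not yet measured; it stands to compound 3 as compound 2 stands to compound 1, (chloro in place of fluoro on an aromatic carbon), and the place is described in the same words, so the change is the same one. Because the earlier step of a number 2 percentage points higher from compound 1 to compound 2 (within the scatter) stayed within the scatter, the new step is expected to be a number 1 percentage points higher from compound 3 to compound 4 (within the scatter). Because compound 3 already gives 90%, little room remains upward. For compound 4 in this assay a value of 91% is estimated, expected between 84% and 97%.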

Compound 4, a percentage reported as inhibition, at one concentration (the size of the read-out at that concentration, not a potency): 91%
The estimate for compound 4 equals the measured number at the digits printed; the measured number falls inside the stated range.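

In this assay, the step for chloro in place of fluoro on an aromatic carbon on the second core is a number 1 percentage points higher from compound 3 to compound 4 (within the scatter), and it reads the same as the step on the first core: the same change on two cores in this assay, a number 2 percentage points higher (within the scatter) from compound 1 to compound 2 and a number 1 percentage points higher (within the scatter) from compound 3 to compound 4, 1 percentage points apart, within the scatter of two such steps. Across these two cores, then, the change carries over in the limited sense that neither step moves the read-out beyond the scatter, so the swap can be treated as neutral in this assay for these two pairs. This does not show that a real effect transfers between cores: with a single tested concentration and compound 4 at 91%, alongside the similar values of the other three compounds, any difference in potency between fluoro and chloro analogues could stay hidden.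

As far as these compounds go, it remains open whether these compounds would separate in a full concentration series or at a lower tested concentration. From the compounds shown here alone, it is also open how the series responds when the halogen on that aromatic carbon gives way to a group of another kind, such as a nitrile, an amine or a carboxylic acid.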